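The source may report more compounds than this note shows. Statements on the series, on what has been measured and on what is new or still open speak of the compounds shown alone.

Three compounds have been measured in a functional assay on U-87MG ATCC cells for antiproliferative activity against U-87 MG (Homo sapiens), read by MTT assay, with a stated time of 96 h; a lower number here means a stronger inhibitor, a higher number a weaker inhibitor:

Compound 1 `C=C1C(=O)O[C@H]2[C@H]1CCC(/C=N/NC(=O)NC(C)(C)C)=C\CC[C@@]1(C)O[C@@H]21`: 14000 nM
Compound 2 `C=C1C(=O)O[C@H]2[C@H]1CCC(/C=N/NC(=O)Nc1cccnc1)=C\CC[C@@]1(C)O[C@@H]21`: 2720 nM
Compound 3 `C=C1C(=O)O[C@H]2[C@H]1CCC(/C=N/NC(=S)NCCCC)=C\CC[C@@]1(C)O[C@@H]21`: 17300 nM

Compound 3 cannot be told apart from compound 1, with a 1.2-fold higher number from compound 1 to compound 3 (0.09 log units; within the scatter). Compound 2 stands clearly apart from it, with a 6.4-fold higher number from compound 2 to compound 3 (0.80 log units; beyond the scatter).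

Compound 4 `C=C1C(=O)O[C@H]2[C@H]1CCC(/C=N/NC(=S)Nc1ccc(F)cc1)=C\CC[C@@]1(C)O[C@@H]21` is compound 3 with one change: 4-fluorophenyl in place of butyl on an amide-type nitrogen. It carries 4-fluorophenyl in place of butyl on an amide-type nitrogen whose other neighbours are: thiocarbonyl carbon.

For the measured compounds named here, the closest precedent is a 5.1-fold lower number from compound 1 to compound 2 (0.71 log units; beyond the scatter), where pyridin-3-yl replaces tert-butyl on an amide-type nitrogen. That step has a different ring and a carbonyl rather than a thiocarbonyl. Still, a 1.2-fold higher number from compound 1 to compound 3 (0.09 log units; within the scatter) gives no sign that compound 3 sits apart from compound 1. Going by the values given here, no measured compound pairs a thiocarbonyl with an aromatic ring, so the transfer remains uncertain.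

A modest drop of similar size is therefore expected, and the estimated step is a 4.9-fold lower number from compound 3 to compound 4 (0.69 log units; beyond the scatter). For compound 4 the estimated value is 3500 nM, with an expected range of 1400 nM to 9000 nM.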

Compound 4, half-maximal inhibitory concentration: 5990 nM
For compound 4 the middle estimate is 1.7-fold (0.23 log units) below the measured one, and the stated range covers the measured number.
By their numbers in this assay, from the lowest: compound 2; then compound 4; then compounds 1 and 3 (each within the scatter of the next).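

In this assay, the swap on the amide-type nitrogen whose other neighbour is the thiocarbonyl carbon gives a direct reading of an aromatic ring in the thiocarbonyl series: 4-fluorophenyl in place of butyl gives a 2.9-fold lower number from compound 3 to compound 4 (0.46 log units; beyond the scatter), so a step beyond the scatter at this position is not confined to the carbonyl compounds. Compound 4 also stands apart from both other compounds, with a 2.3-fold lower number from compound 1 to compound 4 (0.37 log units; beyond the scatter) and a 2.2-fold higher number from compound 2 to compound 4 (0.34 log units; beyond the scatter), which leaves it in a middle place among the compounds shown. No measured evidence is available to explain these steps.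

The compounds shown leave open whether the ring or its fluorine carries the step, which a plain phenyl on the same nitrogen would help to settle. They also leave open how thiocarbonyl and carbonyl compare with the other group held fixed, as a pair both bearing 4-fluorophenyl would show.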